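From 3-methoxyphenyl to 2-bromophenyl on a carbonyl carbon

The compounds below may be only part of what the source reports. "The series", "measured", "known", "first", "only" and "open" are said of these compounds alone.

Values measured in an ADME assay on HEK293 cells (Homo sapiens) for cytotoxicity, read by MTT assay, with a stated time of 72 h (a higher number here means a weaker inhibitor, a lower number a stronger inhibitor), are as follows:
- Compound 1 `COc1ccc2[nH]cc(CCCN3CCN(C(=O)CN4CCN(C(=O)c5ccccc5)CC4)CC3)c2c1` gives > 200000 nM (a limit)
- Compound 2 `COc1ccc2[nH]cc(CCCN3CCN(C(=O)CN4CCN(C(=O)c5ccc(Cl)cc5)CC4)CC3)c2c1` gives 117000 nM (a number)
- Compound 3 `COc1cccc(C(=O)N2CCN(CC(=O)N3CCN(CCCc4c[nH]c5ccc(OC)cc45)CC3)CC2)c1` gives > 200000 nM (a limit)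

Compound 3 stands at > 200000 nM as a limit of the assay, not as a number. Compound 1 also stands at a limit, > 200000 nM in the same assay. Only compound 2 gives a number, 117000 nM as measured.

Compound 4 `COc1ccc2[nH]cc(CCCN3CCN(C(=O)CN4CCN(C(=O)c5ccccc5Br)CC4)CC3)c2c1` has 2-bromophenyl in place of 3-methoxyphenyl on a carbonyl carbon. Going by the values given here, three measured steps bear on this change. The chloro step shows an at least 1.7-fold lower number from compound 1 to compound 2 (0.23 log units; that floor lies within the scatter) and is the nearest guide, although it rests on a single compound. The exchange of whole groups shows an at least 1.7-fold higher number from compound 2 to compound 3 (0.23 log units; that floor lies within the scatter) as the closest step in kind. The methoxy step shows a step that the two limits leave unreadable from compound 1 to compound 3 and so offers no size.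

Going by compound 2 at 117000 nM in this assay, a small move toward a lower number is expected, hard to separate from the scatter. The expected step is (an at least 1.4-fold lower number from compound 3 to compound 4 (0.15 log units; that floor lies within the scatter)). The estimate for compound 4 is 140000 nM and the expected range runs from 70000 nM to 200000 nM in this assay.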

Compound 4, half-maximal inhibitory concentration: 163000 nM
Beside the measured number, compound 4's estimate is 1.2-fold (0.07 log units) below it, and the stated range covers the measured number.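

In this assay, compound 4 gives a readable number, and compound 2 and compound 4, the two compounds shown with a halogen on this aromatic ring, are the only ones that do. The steps from the compounds without a halogen are an at least 1.2-fold lower number from compound 3 to compound 4 (0.08 log units; that floor lies within the scatter) and an at least 1.2-fold lower number from compound 1 to compound 4 (0.08 log units; that floor lies within the scatter), and both remain floors within the scatter because those two starting compounds sit at a limit: the limit of > 200000 nM in this assay, at which 2 of the 4 values shown sit. The comparison between the two halogen-bearing groups is a 1.4-fold higher number from compound 2 to compound 4 (0.14 log units; within the scatter), so 2-bromophenyl and 4-chlorophenyl on this carbonyl carbon cannot be told apart in this assay.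

With every readable step inside the scatter, the compounds shown leave open whether a halogen on this ring truly lowers the number, and whether the identity of the halogen or its place on the ring has any bearing on it. They also leave open how 4-bromophenyl, 2-chlorophenyl or a phenyl ring carrying an amine or a carboxylic acid would read in this assay.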